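The source may hold more compounds than are shown below. What is called first, only, known or untested is meant among the compounds shown, and "the series" means these compounds.

Measured in a functional assay on K562 cells (Homo sapiens) for cytotoxicity, read by sulforhodamine B assay; on this read-out lower numbers stand for higher toxicity in this test and higher numbers for lower toxicity in this test:
- compound 1 `CC1=CC[C@@H]([C@@](C)(O)CCCC(C)(C)NC(=S)NN)CC1`: 9580 nM
- compound 2 `CC1=CC[C@@H]([C@@](C)(O)CCCC(C)(C)NC(=S)N/N=C\c2ccccc2)CC1`: > 100000 nM (a limit)
- compound 3 `CC1=CC[C@@H]([C@@](C)(O)CCCC(C)(C)NC(=S)N/N=C\c2ccc(N(C)C)cc2)CC1`: > 100000 nM (a limit)

Compound 3 stands at a limit and not at a number, which is the limit of > 100000 nM in this assay, at which 2 of the 3 values shown sit. Compound 4 `CC1=CC[C@@H]([C@@](C)(O)CCCC(C)(C)NC(=S)N/N=C\c2ccc([N+](=O)[O-])cc2)CC1` carries nitro in place of dimethylamino on an aromatic carbon. The closest measured change, a step that the two limits leave unreadable from compound 2 to compound 3, sits at the same place on the ring, but it cannot be sized. Within the data shown here, the one readable change, an at least 10-fold higher number from compound 1 to compound 2 (1.01 log units; beyond the scatter), is large and brings in the aromatic ring that compound 4 keeps. Compound 4 is therefore expected to remain near compound 3 in this assay, with no step beyond the scatter. The expected change is a number no higher from compound 3 to compound 4 (the limit leaves the size open). For compound 4 the estimated value is 100000 nM, with an expected range from 20000 nM to 200000 nM.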

Compound 4, concentration lethal to 50% of the cells: 45500 nM
Compound 4: middle estimate off by 2.2-fold (0.34 log units), on the high side; measured number inside the range.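

In this assay, the aromatic carbon para to a large group now yields a readable change: nitro in place of dimethylamino gives an at least 2.1-fold lower number from compound 3 to compound 4 (0.34 log units; beyond the scatter), and nitro in place of hydrogen gives an at least 2.1-fold lower number from compound 2 to compound 4 (0.34 log units; beyond the scatter). A group at this carbon can therefore bring the number down from the limit, which the earlier pair could not show, as the step between those two limits cannot be read: the limit of > 100000 nM in this assay, at which 2 of the 4 values shown sit.

As far as these compounds go, whether methoxy, chlorine or a carboxylic acid at this carbon would also do so stays open. So does whether nitro would give the same step elsewhere on the ring.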